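Adding a Methoxy Group to Compound 3

This account rests on a few compounds, and the source may have more. Where it says the series, first, only, none or still open, it means among the compounds named here.

Compound 1 `Cn1c2cnc1OCCCCCCCCOc1cc3ccccc3cc1-2` gives 23000 nM
Compound 2 `Cn1c2cnc1OCCCCCCCCCCOc1ccccc1-2` gives 31000 nM
Compound 3 `C=CCCCCOc1ccccc1-c1cnc(OCCC=C)n1C` gives 17000 nM

All three values come from a functional assay on SK-MEL-28 cells (Homo sapiens) for inhibition, read by colorimetric assay and MTT assay, with a stated time of 72 h (on this read-out lower numbers stand for stronger inhibition and higher numbers for weaker inhibition), and are close together. Compound 3 (17000 nM) lies within the usual scatter of both compound 1 and compound 2, so these numbers do not separate it from either one.

Compound 4 `C=CCCCCOc1ccc(OC)cc1-c1cnc(OCCC=C)n1C` carries a single change from compound 3 (methoxy in place of hydrogen on an aromatic carbon) with methoxy in place of hydrogen on an aromatic carbon, para to a (hex-5-en-1-yl)oxy group. The measured compounds differ from one another in more than one place, so none of them shows on its own what such a change does. Without that evidence, no shift beyond the scatter is expected in either direction. The estimated 1.1-fold lower number from compound 3 to compound 4 (0.05 log units; within the scatter) therefore stays within the scatter of repeated measurements. For compound 4 the estimated value is 15000 nM with an expected range from 6000 nM to 40000 nM in this measurement.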

Compound 4, half-maximal inhibitory concentration: 62000 nM
Compound 4: the middle estimate sits 4.1-fold (0.62 log units) below what was measured, and the stated range ends below it.
By their numbers in this assay, from the lowest: compounds 3, 1, 2 and 4 (each within the scatter of the next, the first and the last beyond it).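

In this assay, putting methoxy in place of hydrogen on an aromatic carbon, para to a (hex-5-en-1-yl)oxy group, gives a 3.6-fold higher number from compound 3 to compound 4 (0.56 log units; beyond the scatter), so this one change weakens inhibition by a modest but real step. Among these compounds, this is the first comparison here that isolates a single change, and it shows that this position on the ring does not tolerate every substituent without loss. The data give no measured property that would explain the loss.

Going by these compounds, it remains open whether the loss is specific to methoxy, since a hydroxyl group, a fluorine atom or an amine at this position could behave differently. On these data alone, it is also open whether methoxy would have the same effect at another carbon of this ring or on compound 2.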